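This account rests on a few compounds, and the source may have more. Where it says the series, first, only, none or still open, it means among the compounds named here.

Measured in a functional assay on A549 cells (Homo sapiens) for inhibition, read by colorimetric assay and MTT assay, with a stated time of 72 h; on this read-out higher numbers stand for weaker inhibition and lower numbers for stronger inhibition:
- compound 1 `Cn1c2cnc1OCCCCCCCCCCOc1ccccc1-2`: 48000 nM
- compound 2 `C=CCCCCOc1ccccc1-c1cnc(OCCC=C)n1C`: 9000 nM
- compound 3 `CCCCOc1ncc(-c2ccccc2OC)n1C`: 87000 nM

The numbers for compound 3 and compound 1 lie within the usual scatter of each other, while compound 2 stands clearly lower than both. Compound 4 `COc1ccccc1-c1cnc(OCCCc2ccccc2)n1C` has not been measured. It differs from compound 3 by phenyl in place of methyl on a saturated chain carbon, three bonds along the chain from an oxygen on an aromatic ring, which means phenyl in place of methyl on a saturated chain carbon, three bonds along the chain from an oxygen on an aromatic ring. Among the measured compounds shown here, no measured pair shows this change directly. The only hint is that, with bigger side groups than compound 3, compound 2 stands at 9000 nM. A moderate move to a lower number is therefore expected in this assay, an estimated 3.5-fold lower number from compound 3 to compound 4 (0.54 log units; beyond the scatter). For compound 4 the estimated value is 25000 nM, with an expected range of 8000 nM to 80000 nM.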

Compound 4, half-maximal inhibitory concentration: 3000 nM
Estimate against measurement, compound 4: 8.3-fold (0.92 log units) above, outside the stated range (below it).
By their numbers in this assay, from the lowest: compound 4; then compound 2; then compounds 1 and 3 (each within the scatter of the next).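

In this assay, among the compounds shown here, the swap of methyl for phenyl at the end of this chain gives a 29-fold lower number from compound 3 to compound 4 (1.46 log units; beyond the scatter) and so offers the first direct reading at this position. A six-membered aromatic ring is accepted here, and the number falls far beyond the scatter. Nothing available explains why this step is so large.

Cyclohexyl in the same place could show whether the ring must be aromatic. A longer chain carrying the phenyl, or an amine on that ring, could show how far this change can be taken.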